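The source may report more compounds than this note shows. Statements on the series, on what has been measured and on what is new or still open speak of the compounds shown alone.

Measured compounds:
compound 1, `C=C1C(=O)[C@]23C[C@@]1(O)CC[C@H]2c1ccc(O)c(C)c1[C@@H]3Cn1cc(-c2ccc(C(F)(F)F)cc2)nn1`: 370 nM
compound 3, `C=C1C(=O)[C@]23C[C@@]1(O)CC[C@H]2c1ccc(O)c(C)c1[C@@H]3Cn1cc(-c2ccc(C)cc2)nn1`: 330 nM
compound 2, `Cc1c(O)ccc2c1[C@H](Cn1cc(-c3ccc(C(F)(F)F)cc3)nn1)[C@@]13CC(=O)[C@@](C)(CC[C@@H]21)C3`: a limit only, > 20000 nM

In a functional assay on SW480 cells (Homo sapiens) for cytotoxicity, read by MTT assay, with a stated time of 4 days (a higher number here means a weaker inhibitor, a lower number a stronger inhibitor), compound 1 gives 370 nM and compound 3 gives 330 nM. The change between them, (methyl in place of trifluoromethyl on an aromatic carbon), makes a 1.1-fold lower number from compound 1 to compound 3 (0.05 log units; within the scatter). Compound 2 carries a different core; the difference between the two cores is not broken down here. In this assay compound 2 gives only a limit of the assay, > 20000 nM. That value is the limit of > 20000 nM in this assay, at which 1 of the 3 values shown sits.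

Compound 4, `Cc1ccc(-c2cn(C[C@H]3c4c(ccc(O)c4C)[C@@H]4CC[C@@]5(C)C[C@]43CC5=O)nn2)cc1`, repeats the same change on the core of compound 2: methyl in place of trifluoromethyl on an aromatic carbon. Since the same change from compound 1 to compound 3 gave a 1.1-fold lower number from compound 1 to compound 3 (0.05 log units; within the scatter), a step of similar size is expected here, a step that the limit leaves unreadable from compound 2 to compound 4. Compound 4 is therefore expected to sit at 30000 nM, most likely again reported only as a limit, with a range of 12000 nM to 80000 nM.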

Compound 4, half-maximal inhibitory concentration: > 20000 nM
Compound 4: a limit, no number; the forecaster's own chance of this, stated with the estimate: 85%; the middle value lies beyond the limit too.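

Compound 2 and compound 4 both stand only as limits in this assay, so no step can be read between them: the limit of > 20000 nM in this assay, at which 2 of the 4 values shown sit.

Left open is whether methyl in place of trifluoromethyl shifts the number at all on the core of compound 2.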